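Half-life notes: iodo in place of cyano

A few compounds are considered here, and "the series" means these few. Any claim that something is new, unique, unknown or untested is made for them only; others in the source may bear on it.

Measured so far in an ADME assay on microsomes from liver (Rattus norvegicus) for metabolic stability; on this read-out lower numbers stand for a shorter-lived compound and higher numbers for a longer-lived compound:
- compound 1 `CC#C[C@@H](Cc1nnn[nH]1)c1ccc(OCc2ccc3scc(-c4cccnc4C)c3c2)cc1` gives 0.183 h
- compound 2 `CC#C[C@@H](Cc1nnn[nH]1)c1ccc(OCc2ccc3sc(C#N)c(-c4ccccc4C)c3c2)cc1` gives 0.533 h

Compound 2 holds the higher of the two numbers, and compound 1 lies lower by more than the usual scatter. Going by the values given here, these two compounds differ in more than one place, so no single-change step has been measured. Compound 3 `CC#C[C@@H](Cc1nnn[nH]1)c1ccc(OCc2ccc3sc(I)c(-c4ccccc4C)c3c2)cc1` follows from compound 2 with iodo in place of cyano on an aromatic carbon, next to the ring sulfur (iodo in place of cyano on an aromatic carbon). Neither measured compound carries iodo, so nothing measured speaks directly to this exchange. In this assay no step beyond the scatter is expected, and the range stays wide on both sides. The estimate is a 1.3-fold lower number from compound 2 to compound 3 (0.10 log units; within the scatter). For compound 3 the expected value is 0.42 h, with an estimated range of 0.18 h to 0.95 h.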

Compound 3, half-life: 0.483 h
The estimate for compound 3 lay 1.2-fold (0.06 log units) below the measured number; the measured number falls inside the stated range.
By their numbers in this assay, from the lowest: compound 1; then compounds 3 and 2 (each within the scatter of the next).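

In this assay, going by these compounds alone, the exchange of cyano for iodo on the aromatic carbon next to the ring sulfur gives a 1.1-fold lower number from compound 2 to compound 3 (0.04 log units; within the scatter) and provides the only single-change step so far. At this position, the two groups cannot be told apart on this read-out, even though the cyano group has two heavy atoms, a triple bond and a hydrogen-bond acceptor, whereas iodo has one heavy atom and no acceptor. No measurement is available that would explain this outcome.

On these data alone, how a methyl group, an amine or a carboxylic acid on this same carbon would read remains open. Compound 1 differs from both compound 2 and compound 3 in more than one place, so it cannot separate the contribution of this position from that of the other differences.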